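Amino to fluoro in a cytotoxic pair

The compounds below may be only part of what the source reports. "The series", "measured", "known", "first", "only" and "open" are said of these compounds alone.

Of the compounds shown here, two have been tested so far in a functional assay on NCI-H460 cells (Homo sapiens) for cytotoxicity, read by MTT assay, with a stated time of 68 h (a lower number here means a stronger inhibitor, a higher number a weaker inhibitor), and neither gave a number. Compound 1 (`COc1ccc(-c2cc(NC(=O)C(Cl)Cl)cc(-c3ccc(OC)cc3)c2)cc1`) gives > 30000 nM as a limit of the assay. Compound 2 (`Nc1cccc(-c2cccc(NC(=O)C(Cl)Cl)c2)c1`) gives > 50000 nM as a limit of the assay as well. Among the compounds with values here, compound 2 thus has no exact position on the scale, and no measured step shows how a structural change moves the read-out. Compound 3 (`O=C(Nc1cccc(-c2cccc(F)c2)c1)C(Cl)Cl`) differs from compound 2 in one place, with fluoro in place of amino on an aromatic carbon, meta to a large group (fluoro in place of amino on an aromatic carbon). A modest move toward a lower number is expected in this assay, though another limit remains possible. The expected change is an at least 2.0-fold lower number from compound 2 to compound 3 (0.30 log units; that floor lies within the scatter) and remains an estimate. For compound 3 the estimated value is 25000 nM with an expected range from 8000 nM to 60000 nM in this assay.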

Compound 3, half-maximal inhibitory concentration: > 50000 nM
Compound 3 ended at the assay's limit; the forecaster's own chance of this, stated with the estimate: 35%; middle value at least 2.0-fold (0.30 log units) from the limit.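

The step from compound 2 to compound 3 cannot be read, because both compounds stand at the same limit: the limit of > 50000 nM in this assay, at which 2 of the 3 values shown sit. The compounds shown leave open how fluoro in place of amino moves the read-out in this assay, and whether any change to the shared core gives an exact value there.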